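The source may hold more compounds than are shown below. What is called first, only, known or untested is meant among the compounds shown, and "the series" means these compounds.

Of the compounds shown here, three built on a shared core have so far been tested in an assay on HeLa cells for agonist activity at Bile acid receptor (Homo sapiens), read by a luciferase reporter, with a stated time of 24 h; on this read-out lower numbers stand for an effect already at smaller amounts and higher numbers for an effect only at larger amounts of compound. Compound 1 `COc1ccc(-c2nc(-c3cccc(C(F)(F)F)c3)no2)cc1` gives 2900 nM. Compound 2 `COc1ccc(-c2nc(-c3ccccc3C)no2)cc1` gives 120 nM in this assay, and compound 3 `Cc1ccc(-c2noc(-c3ccc(Cl)cc3)n2)cc1` gives 410 nM. Compound 2 therefore stands at the lowest number of the three, which on this read-out means it acts at the smallest amount: the nearest of the other two is compound 3, whose gap to compound 2 already lies beyond the scatter of repeated measurements, and the furthest is compound 1, whose gap is wider still.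

The next compound, compound 4 `Cc1ccccc1-c1noc(-c2ccc(C(=O)O)cc2)n1`, differs from compound 2 in a single place: carboxy in place of methoxy on an aromatic carbon. Going by the values given here, no measured pair in this set differs only in this way, so the numbers at hand give no direct guide to how the exchange plays out. The expectation rests on compound 2 alone, with its value of 120 nM, and the step from compound 2 to compound 4 is estimated at a 1.5-fold higher number from compound 2 to compound 4 (0.18 log units; within the scatter), which I expect to stay within the scatter, though with wide uncertainty in both directions. Compound 4 is accordingly expected to give about 180 nM in this assay, with a range from 40 nM to 1000 nM.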

Compound 4, half-maximal effective concentration: 220 nM
Beside the measured number, compound 4's estimate is 1.2-fold (0.09 log units) below it, within the range that was stated.
By their numbers in this assay, from the lowest: compounds 2, 4 and 3 (each within the scatter of the next, the first and the last beyond it); then compound 1.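

In this assay, putting carboxy in place of methoxy on an aromatic carbon, para to a large group, gives a 1.8-fold higher number from compound 2 to compound 4 (0.26 log units; within the scatter), so this read-out does not separate the two compounds. Going by these compounds alone, this is the first direct reading of a single exchange in the set, and it shows that this position can hold carboxy, which brings a hydrogen-bond donor and a double bond outside the aromatic rings, with a difference no larger than the usual scatter. Nothing available explains why the two groups read so alike.

Going by these compounds, with only methoxy and carboxy compared at this position, it remains open how an amine, a hydroxy group or a primary amide would read there. Also open, on these data alone, is whether the exchange from methoxy to carboxy would read the same way with a different group on the other aromatic ring, such as the trifluoromethyl group of compound 1.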